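A few compounds are considered here, and "the series" means these few. Any claim that something is new, unique, unknown or untested is made for them only; others in the source may bear on it.

Measured in a functional assay on cells (Homo sapiens), read by thymidine incorporation; a higher number here means a weaker inhibitor, a lower number a stronger inhibitor:
Compound 1 `Cc1cc(NCc2cccnc2)n2ncc(Br)c2n1`: 1800 nM
Compound 2 `CC(O)c1cc(NCc2cccnc2)n2ncc(Br)c2n1`: 1400 nM
Compound 3 `CCOC(=O)c1cc(NCc2cccnc2)n2ncc(Br)c2n1`: 2900 nM

Compound 1 stands within the scatter of both other compounds, as a 1.3-fold lower number from compound 1 to compound 2 (0.11 log units; within the scatter) and a 1.6-fold higher number from compound 1 to compound 3 (0.21 log units; within the scatter) show. Only a 2.1-fold higher number from compound 2 to compound 3 (0.32 log units; beyond the scatter) passes the scatter, and modestly so.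

Compound 4 `COc1cc(NCc2cccnc2)n2ncc(Br)c2n1` differs from compound 1 at that same aromatic carbon, next to the ring nitrogen: methoxy in place of methyl on an aromatic carbon, methoxy in place of methyl. The two measured replacements of that methyl are the closest guide, and both stayed within the scatter. A step beyond the scatter is therefore not expected in this assay, and no direction can be called. The expected change is a 1.1-fold higher number from compound 1 to compound 4 (0.02 log units; within the scatter). Compound 4 is estimated at 1900 nM, with an expected range of 900 nM to 4000 nM.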

Compound 4, half-maximal inhibitory concentration: 2000 nM
Compound 4: middle estimate off by 1.1-fold (0.02 log units), on the low side; low and high end bracket the measured number.
By their numbers in this assay, from the lowest: compounds 2, 1, 4 and 3 (each within the scatter of the next, the first and the last beyond it).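

In this assay methoxy in place of methyl gives a 1.1-fold higher number from compound 1 to compound 4 (0.05 log units; within the scatter) and so adds a third replacement of that methyl that stays inside the scatter. Set against the other two replacements, methoxy gives a 1.5-fold lower number from compound 3 to compound 4 (0.16 log units; within the scatter) and a 1.4-fold higher number from compound 2 to compound 4 (0.15 log units; within the scatter) and so shows no step past the scatter from either. Nothing available explains this result.

On these data alone, whether an amine or a carboxylic acid on this aromatic carbon would move the number past the scatter remains open. The same holds for a longer chain.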